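Benzothiazole for Benzoxazole: Expected Cytotoxicity of Compound 3

The source may report more compounds than this note shows. Statements on the series, on what has been measured and on what is new or still open speak of the compounds shown alone.

Measured so far:
compound 1, `Clc1ccc(Cn2cncc2CNc2cccc(-c3ccccc3)c2)cc1`: 10000 nM
compound 2, `c1ccc(-c2ccc(Cn3cncc3CNc3ccc(-c4nc5ccccc5o4)c(-c4ccccc4)c3)cc2)cc1`: > 10000 nM

Of the compounds shown here, two have been tested in a toxicity assay on NIH3T3 cells (Mus musculus) for cytotoxicity, read by resazurin assay; on this read-out lower numbers stand for an effect already at smaller amounts and higher numbers for an effect only at larger amounts of compound. Compound 1 `Clc1ccc(Cn2cncc2CNc2cccc(-c3ccccc3)c2)cc1` gives 10000 nM. For compound 2 `c1ccc(-c2ccc(Cn3cncc3CNc3ccc(-c4nc5ccccc5o4)c(-c4ccccc4)c3)cc2)cc1` only a limit is known: in this assay compound 2 gives > 10000 nM, which is a limit of the assay and not a number. Among the compounds with values here, compound 2 therefore stands at the limit of > 10000 nM in this assay, at which 1 of the 2 values shown sits, and no step between two measured compounds can be drawn from these two values.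

Compound 3 `c1ccc(-c2ccc(Cn3cncc3CNc3ccc(-c4nc5ccccc5s4)c(-c4ccccc4)c3)cc2)cc1` differs from compound 2 in one place: 1,3-benzothiazol-2-yl in place of 1,3-benzoxazol-2-yl on an aromatic carbon. In this assay no change beyond the usual scatter is expected from this swap, so the step from compound 2 to compound 3 is expected to be a step that the limit leaves unreadable from compound 2 to compound 3. For compound 3 the estimated value is 15000 nM, with a range from 7000 nM to 40000 nM, and it will most likely again be reported only as a limit.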

Compound 3, half-maximal effective concentration: > 1000 nM
Compound 3 ended at the assay's limit (the forecaster's own chance of this, stated with the estimate: 70%); the middle value is on the limit's open side.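

Compound 3 gives > 1000 nM, which is a limit of the assay and not a number. Within the data shown here, compound 2 also stands only at a limit, so no step from compound 2 to compound 3 can be read. On these data alone, whether 1,3-benzothiazol-2-yl and 1,3-benzoxazol-2-yl differ in this assay stays open.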